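The source may hold more compounds than are shown below. What is called first, only, known or untested is meant among the compounds shown, and "the series" means these compounds.

Compound 1 (`CCn1cc(Nc2ncc(Cl)c(N[C@H]3[C@@H](C(N)=O)[C@@H]4C=C[C@H]3C4)n2)cn1`) carries ethyl on an aromatic nitrogen, and in a physicochemical assay for solubility, read by chemiluminescence, with a stated time of 24 h, at pH 7.4 (on this read-out lower numbers stand for lower solubility and higher numbers for higher solubility), compound 1 gives 70000 nM. Compound 2 (`NC(=O)[C@@H]1[C@H](Nc2nc(Nc3cnn([C@@H]4CCCNC4)c3)ncc2Cl)[C@H]2C=C[C@@H]1C2`) shares the same core but has piperidin-3-yl on that nitrogen, and in this assay compound 2 gives 70000 nM, which leaves it level with compound 1. Compound 3 (`NC(=O)Cn1cc(Nc2ncc(Cl)c(N[C@H]3[C@@H](C(N)=O)[C@@H]4C=C[C@H]3C4)n2)cn1`) keeps the core again and has carbamoylmethyl in place of piperidin-3-yl on the aromatic nitrogen: carbamoylmethyl in place of piperidin-3-yl on an aromatic nitrogen. Going by the values given here, only one measured step bears on this change, as it involves the same nitrogen: no change at the digits printed from compound 1 to compound 2 (within the scatter). That exchange of one group for a much larger one left the number where it was, so no step beyond the scatter is expected here, although a single step is thin evidence. The expected step is no change at the digits printed from compound 2 to compound 3 (within the scatter). Compound 3 is estimated at 70000 nM, with an expected range from 30000 nM to 110000 nM.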

Compound 3, solubility: 68000 nM
For compound 3 the middle estimate is 1.0-fold (0.01 log units) above the measured one, and the stated range covers the measured number.
By their numbers in this assay, from the lowest: compounds 3, 1 and 2 (each within the scatter of the next).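

In this assay, carbamoylmethyl in place of piperidin-3-yl on the aromatic nitrogen gives a 1.0-fold lower number from compound 2 to compound 3 (0.01 log units; within the scatter), while carbamoyl in place of the terminal methyl of the ethyl group gives a 1.0-fold lower number from compound 1 to compound 3 (0.01 log units; within the scatter). Going by these compounds alone, the earlier pair showed only that a ring-bearing group could replace ethyl at this nitrogen without moving the number beyond the scatter; now a group with no ring and with a carbonyl also stays within the scatter of both, so ethyl, piperidin-3-yl and carbamoylmethyl cannot be told apart on this read-out. No measurement given here accounts for this flat result.

These three compounds leave open whether a carboxylic acid, a longer chain or an aromatic ring on this nitrogen would also stay within the scatter. They also say nothing about changes elsewhere on the shared core.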